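A 4-nitrophenyl swap in a flat cytotoxicity series

The source may hold more compounds than are shown below. What is called first, only, known or untested is meant among the compounds shown, and "the series" means these compounds.

Of the compounds shown here, three sharing one core have been tested in an ADME assay on MDCK cells (Canis lupus familiaris) for cytotoxicity, read by MTT assay, with a stated time of 48 h; on this read-out higher numbers stand for lower toxicity in this test and lower numbers for higher toxicity in this test. Compound 1 `CC(C)(C)c1ccc(-c2cn(CC3=C(Cl)c4ccc(-c5cccs5)nc4CC3)nn2)cc1` gives 172 ug/mL, compound 2 `Fc1ccc(-c2cn(CC3=C(Cl)c4ccc(-c5cccs5)nc4CC3)nn2)cc1` gives 100 ug/mL, and compound 3 `Fc1ccc(-c2cn(CC3=C(Cl)c4ccc(-c5cccs5)nc4CC3)nn2)c(F)c1` gives 188 ug/mL. These numbers all sit within the usual scatter of one another, so compound 3 does not stand apart from the other two. The next structure, compound 4 `O=[N+]([O-])c1ccc(-c2cn(CC3=C(Cl)c4ccc(-c5cccs5)nc4CC3)nn2)cc1`, carries a new group: 4-nitrophenyl in place of 2,4-difluorophenyl on an aromatic carbon. In words, 4-nitrophenyl takes the place of 2,4-difluorophenyl on an aromatic carbon. Among the measured compounds shown here, three measured steps bear on this, each altering the group at this same place: a 1.7-fold lower number from compound 1 to compound 2 (0.24 log units; within the scatter), a 1.1-fold higher number from compound 1 to compound 3 (0.04 log units; within the scatter) and a 1.9-fold higher number from compound 2 to compound 3 (0.27 log units; within the scatter). All three stay within the scatter, but none brings in a 4-nitrophenyl group, so the guidance is only indirect. No change beyond the scatter is expected, in either direction. The expected step is a 1.3-fold lower number from compound 3 to compound 4 (0.13 log units; within the scatter). For compound 4 the estimated value in this assay is 140 ug/mL, with an expected range of 70 ug/mL to 280 ug/mL.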

Compound 4, half-maximal cytotoxic concentration: 40 ug/mL
Beside the measured number, compound 4's estimate is 3.5-fold (0.54 log units) above it; the measured number lies below the stated range.
By their numbers in this assay, from the lowest: compound 4; then compounds 2, 1 and 3 (each within the scatter of the next).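

Until now, swapping the group at this place on the five-membered aromatic ring left the number within the scatter in this assay, so the site looked tolerant. Among the compounds shown here, the 4-nitrophenyl group is the first to move the number beyond the scatter, with a 4.7-fold lower number from compound 3 to compound 4 (0.67 log units; beyond the scatter) and a 2.5-fold lower number from compound 2 to compound 4 (0.40 log units; beyond the scatter) as well as a 4.3-fold lower number from compound 1 to compound 4 (0.63 log units; beyond the scatter), all modest steps that make compound 4 the most toxic of the four in this test. No measurement here explains why this group behaves differently from the others.

This rests on a single compound, so it remains unclear whether the effect belongs to the nitro group alone. A nitrile, an amine or a carboxylic acid in its place would show whether other groups also lower the number.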